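Replacing 5-methylpyridin-3-yl in compound 1

The source may hold more compounds than are shown below. What is called first, only, known or untested is meant among the compounds shown, and "the series" means these compounds.

Within the data shown here, in an ADME assay on the whole organism for pharmacokinetics, with Rattus norvegicus as the target (a higher number here means that a larger share of the oral dose reaches the circulation, a lower number that a smaller share of the oral dose reaches the circulation), compound 1 `COc1nc2ccc(Br)cc2cc1[C@@H](c1cncc(C)c1)[C@@](O)(CCN(C)C)c1cccc(F)c1` gives 24%, the lower of the two numbers so far. Compound 2 `COc1nc2ccc(Br)cc2cc1[C@@H](c1ccnc(OC)c1OC)[C@@](O)(CCN(C)C)c1cccc(C)c1` reaches 40%, a gap beyond the scatter. Compound 3 `COc1cc([C@H](c2cc3cc(Br)ccc3nc2OC)[C@@](O)(CCN(C)C)c2cccc(F)c2)cnc1OC` carries 5,6-dimethoxypyridin-3-yl in place of 5-methylpyridin-3-yl on a saturated chain carbon bound to an aromatic carbon and a saturated chain carbon. Among the measured compounds shown here, no measured pair isolates this change, and compound 2 at 40% differs from compound 1 in more than one place. Only a small rise, not clearly beyond the scatter, is therefore expected in this assay, with an estimated step of a number 6 percentage points higher from compound 1 to compound 3 (within the scatter). For compound 3 the estimated value is 30%, with an expected range from 15% to 46%.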

Compound 3, oral bioavailability: 36%
Estimate against measurement, compound 3: 6 percentage points below; the measured number falls inside the stated range.
By their numbers in this assay, from the lowest: compound 1; then compounds 3 and 2 (each within the scatter of the next).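

Among these compounds, with 5,6-dimethoxypyridin-3-yl in place of 5-methylpyridin-3-yl on the saturated chain carbon, this assay shows a number 12 percentage points higher from compound 1 to compound 3 (beyond the scatter) as the first step in which only this group changes. The larger group, with more hydrogen-bond acceptors by count, therefore comes with a higher number rather than a lower one in this comparison. Nothing given here accounts for the rise.

As far as these compounds go, whether both methoxy groups are needed for this step remains open. From the compounds shown here alone, how an amine on the same pyridine ring would read in this assay also remains open.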